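Swapping Halogenated Phenyl Groups on the Amine Nitrogen

The compounds below may be only part of what the source reports. "The series", "measured", "known", "first", "only" and "open" are said of these compounds alone.

Of the compounds shown here, two sharing one core have been tested in a functional assay on A549 cells (Homo sapiens) for cytotoxicity, read by MTT assay, with a stated time of 48 h; a higher number here means a weaker inhibitor, a lower number a stronger inhibitor. Compound 1 `COc1ccc(N/C(CCNC2=CC(=O)c3ccccc3C2=O)=N\S(=O)(=O)c2ccc(C)cc2)cc1` gives 25500 nM in this assay. Compound 2 `Cc1ccc(S(=O)(=O)/N=C(/CCNC2=CC(=O)c3ccccc3C2=O)Nc2ccc(F)c(F)c2)cc1` gives 16700 nM. Compound 2 has the lowest of the two numbers, but the step of a 1.5-fold lower number from compound 1 to compound 2 (0.18 log units; within the scatter) is too small to count as a real difference, so the two compounds sit together. Compound 3 `Cc1ccc(S(=O)(=O)/N=C(/CCNC2=CC(=O)c3ccccc3C2=O)Nc2ccc(Cl)cc2Cl)cc1` has not yet been measured. It differs from compound 2 in one place: 2,4-dichlorophenyl in place of 3,4-difluorophenyl on an amine nitrogen. For the measured compounds named here, the only measured step that touches this part of the molecule is a 1.5-fold lower number from compound 1 to compound 2 (0.18 log units; within the scatter), where a halogenated phenyl replaced the 4-methoxyphenyl and the number barely moved. On that basis, for compound 3 the change to the 2,4-dichlorophenyl is expected to give no step beyond the scatter, a 1.1-fold lower number from compound 2 to compound 3 (0.05 log units; within the scatter). Compound 3 is therefore estimated at 15000 nM, with a range from 6000 nM to 40000 nM.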

Compound 3, half-maximal inhibitory concentration: 32900 nM
For compound 3 the middle estimate is 2.2-fold (0.34 log units) below the measured one; the measured number falls inside the stated range.
By their numbers in this assay, from the lowest: compounds 2, 1 and 3 (each within the scatter of the next).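

In this assay a third group at this amine nitrogen gives a 2.0-fold higher number from compound 2 to compound 3 (0.29 log units; within the scatter) and also a 1.3-fold higher number from compound 1 to compound 3 (0.11 log units; within the scatter) when set against the 4-methoxyphenyl. Both steps lie within the scatter, so 3,4-difluorophenyl, 2,4-dichlorophenyl and 4-methoxyphenyl cannot be ranked at this position, and the two halogenated phenyl groups show no shared advantage over the 4-methoxyphenyl. Nothing measured here bears on why the three numbers fall where they do.

From the compounds shown here alone, all three compounds carry a substituted phenyl group on this nitrogen, so it remains open whether an unsubstituted phenyl, a benzyl or a pyridine ring there would give a step beyond the scatter. Going by these compounds, it is also open whether a longer chain in the shared core would change the number more than any swap at this nitrogen.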